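This account rests on a few compounds, and the source may have more. Where it says the series, first, only, none or still open, it means among the compounds named here.

Working notes on the series, all read in an ADME assay on microsomes from liver (Rattus norvegicus, strain Sprague-Dawley) for metabolic stability, read by LC-MS, using NADPH, with a stated time of 45 min, tested at 3 uM; a higher number here means that the compound lasts longer, a lower number that the compound disappears faster. Compound 1 (`C1CCC(C(CC2CCCCN2)C2CCC2)CC1`) gives 0.167 h, compound 2 (`C1CCC(C(CC2CCCCN2)C2CCCC2)CC1`) gives 0.317 h and compound 3 (`c1ccc(C(CC2CCCCN2)C2CCCCC2)cc1`) gives 0.0667 h. Compound 3 holds the lowest of the three numbers, and its gap to each of the other two lies beyond the scatter.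

Compound 4 (`C1CCC(C(CC2CCCCN2)C2CCOCC2)CC1`) carries oxan-4-yl in place of the phenyl of compound 3, on a saturated chain carbon bound to a saturated chain carbon and a saturated ring carbon: oxan-4-yl in place of phenyl on a saturated chain carbon bound to a saturated chain carbon and a saturated ring carbon.

Within the data shown here, no measured step brings in oxan-4-yl, so the nearest evidence is the pair of steps that end in phenyl: a 2.5-fold lower number from compound 1 to compound 3 (0.40 log units; beyond the scatter) and a 4.8-fold lower number from compound 2 to compound 3 (0.68 log units; beyond the scatter). Both are modest and beyond the scatter. Read in reverse, they show phenyl giving way to a saturated ring with a higher number, in these three compounds only. The remaining step, a 1.9-fold higher number from compound 1 to compound 2 (0.28 log units; within the scatter), lies within the scatter and gives no direction. The effect of the ring oxygen is not shown by any measurement so far, which widens the range.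

A modest upward step is therefore expected, estimated as a 3.7-fold higher number from compound 3 to compound 4 (0.57 log units; beyond the scatter). For compound 4 the estimated value is 0.25 h, with an expected range from 0.1 h to 0.6 h.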

Compound 4, half-life: 0.517 h
Compound 4: middle estimate off by 2.1-fold (0.32 log units), on the low side; low and high end bracket the measured number.
By their numbers in this assay, from the lowest: compound 3; then compounds 1, 2 and 4 (each within the scatter of the next, the first and the last beyond it).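

Among these compounds, at this position, on a saturated chain carbon bound to a saturated chain carbon and a saturated ring carbon, this assay shows oxan-4-yl in place of phenyl giving a 7.8-fold higher number from compound 3 to compound 4 (0.89 log units; beyond the scatter) and the largest step so far, and compound 3 now stands below all three saturated-ring compounds, each gap beyond the scatter. A saturated ring carrying a hetero atom and a hydrogen-bond acceptor is thus tolerated here as well as the all-carbon rings: a 1.6-fold higher number from compound 2 to compound 4 (0.21 log units; within the scatter) leaves oxan-4-yl and cyclopentyl unordered, whereas a 3.1-fold higher number from compound 1 to compound 4 (0.49 log units; beyond the scatter) puts oxan-4-yl clear of cyclobutyl. No measurement on these compounds accounts for any of these steps.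

The compounds shown leave open whether a ring amine such as piperidin-4-yl, or an open-chain ether such as 2-methoxyethyl, would read with oxan-4-yl or with phenyl at this position. They also leave open whether the step from phenyl to oxan-4-yl carries over to a core other than the one shared here.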